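Glycoside aryl ethers: toward compound 3

This account rests on a few compounds, and the source may have more. Where it says the series, first, only, none or still open, it means among the compounds named here.

Compound 1 `CO[C@H]1O[C@H](COc2ccc(-c3ccccc3)cc2)[C@@H](O)[C@H](O)[C@H]1Oc1ccccc1` and compound 2 `CO[C@H]1O[C@H](COc2ccc(OC3CCCCC3)cc2)[C@@H](O)[C@H](O)[C@H]1Oc1ccc(C(C)C)cc1` share a glycoside core carrying two aryl ether groups. In a functional assay on HeLa cells (Homo sapiens) for cytotoxicity, read by MTT assay, with a stated time of 48 h (a lower number here means that less compound is needed, a higher number that more compound is needed for the effect), compound 1 gives 33000 nM, and compound 2 gives 18000 nM; compound 2 has the lower of the two numbers, but the gap lies within the scatter, so no order can be read from it. Compound 3 `CO[C@H]1O[C@H](COc2ccc(OC3CCCCC3)cc2)[C@@H](O)[C@H](O)[C@H]1Oc1ccc(OC2CCCCC2)cc1` differs from compound 2 in one place (cyclohexyloxy in place of isopropyl on an aromatic carbon), para to a large group. For the measured compounds named here, with no single-change step measured, the step from compound 2 to compound 3 is expected to stay within the scatter, estimated at a 1.2-fold lower number from compound 2 to compound 3 (0.08 log units; within the scatter). Compound 3 is expected near 15000 nM, in the range 6000 nM to 40000 nM.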

Compound 3, half-maximal effective concentration: 14000 nM
Compound 3: the middle estimate sits 1.1-fold (0.03 log units) above what was measured; low and high end bracket the measured number.
By their numbers in this assay, from the lowest: compounds 3, 2 and 1 (each within the scatter of the next, the first and the last beyond it).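

For the compounds shown here, this is the only single-place comparison. In this assay the change to cyclohexyloxy in place of isopropyl on an aromatic carbon, para to a large group, gives a 1.3-fold lower number from compound 2 to compound 3 (0.11 log units; within the scatter) and so shows no readable effect, even though the entering group brings a six-membered non-aromatic ring and a hydrogen-bond acceptor. No supporting data bear on this result.

As far as these compounds go, whether an amine or a carboxylic acid at this position would move the number beyond the scatter remains open. So does the effect of a single change at the other aryl ether.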